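The source may hold more compounds than are shown below. What is called first, only, known or untested is meant among the compounds shown, and "the series" means these compounds.

Compound 1 `CCc1cc(C(C)=O)c(O)cc1OCCCCC#N`: 57%
Compound 2 `CC(=O)c1cc(CC2CO2)c(OCCCCC#N)cc1O`: 24%
Compound 3 `C=CCc1cc(C(C)=O)c(O)cc1OCCCCC#N`: 57%

All three were tested in an assay on isolated protein for binding affinity to leukotriene B4 receptor 1 (Homo sapiens), tested at 1 uM; on this read-out lower numbers stand for less inhibition and higher numbers for more inhibition at the one concentration tested (going by the name of the read-out). Compound 3 stands level with compound 1 at the digits shown, and the two together give the highest numbers of the set; the only large movement is a number 33 percentage points higher from compound 2 to compound 3 (beyond the scatter), whereas no change at the digits printed from compound 1 to compound 3 (within the scatter).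

Compound 4 `C=CCc1cc(C(C)=O)c(O)cc1OCCCCCC(=O)NO` differs from compound 3 in one place: (hydroxycarbamoyl)methyl in place of cyano on a saturated chain carbon, four bonds along the chain from an oxygen on an aromatic ring. Every measured step concerns the group on the saturated chain carbon bound to an aromatic carbon, not the far end of the chain, so none of them speaks to this change. With nothing to lean on, the expected step is a number 12 percentage points lower from compound 3 to compound 4 (beyond the scatter), carrying wide uncertainty. Compound 4 is estimated at 45%, between 15% and 75%.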

Compound 4, a percentage reported as inhibition, at one concentration (the size of the read-out at that concentration, not a potency): 28%
Compound 4: the middle estimate sits 17 percentage points above what was measured; low and high end bracket the measured number.
By their numbers in this assay, from the lowest: compounds 2 and 4 (each within the scatter of the next); then compounds 1 and 3 (each within the scatter of the next).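

In this assay, the far end of the chain proves to matter: placing (hydroxycarbamoyl)methyl instead of cyano gives a number 29 percentage points lower from compound 3 to compound 4 (beyond the scatter) on the same core. For the compounds shown here, the earlier steps changed only the group on the saturated chain carbon bound to an aromatic carbon, so this is the first sign that the chain end also affects the number. No measurement here explains the drop.

The compounds shown do not separate the effect of the hydroxycarbamoyl group from that of the added chain length. A carboxylic acid or an amine at the chain end, or a shorter chain, remains an open comparison.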